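Chloro for butyl on the acetamide chain of the sulfonate series

The compounds below may be only part of what the source reports. "The series", "measured", "known", "first", "only" and "open" are said of these compounds alone.

Compound 2 `CCCCCC(=O)Nc1cccc(S(=O)(=O)Oc2ccccc2C(C)C)c1` gives 12000 nM in a functional assay on MCF7 cells (Homo sapiens) for antiproliferative activity, read by sulforhodamine B assay, with a stated time of 48 h (on this read-out lower numbers stand for stronger inhibition and higher numbers for weaker inhibition), and stands highest of the two numbers measured, nearest compound 1 `CCCC(=O)Nc1cccc(S(=O)(=O)Oc2ccccc2C(C)C)c1` at 9400 nM. The only step shown, a 1.3-fold higher number from compound 1 to compound 2 (0.11 log units; within the scatter), lengthens the chain and sits within the scatter. Compound 3 `CC(C)c1ccccc1OS(=O)(=O)c1cccc(NC(=O)CCl)c1` differs from compound 2 by chloro in place of butyl on a saturated chain carbon bound to a carbonyl carbon, a change cut one bond further out as pentyl to chloromethyl, on which that step bears only loosely. No step beyond the scatter is therefore expected; compound 3 is estimated at 7000 nM (range 1500 nM to 30000 nM), a step of a 1.7-fold lower number from compound 2 to compound 3 (0.23 log units; within the scatter).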

Compound 3, half-maximal inhibitory concentration: 2200 nM
Compound 3: middle estimate off by 3.2-fold (0.50 log units), on the high side; the range from low to high includes it.
By their numbers in this assay, from the lowest: compound 3; then compounds 1 and 2 (each within the scatter of the next).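

In this assay, the saturated chain carbon bound to a carbonyl carbon proves sensitive to the group it carries, which the within-scatter chain lengthening did not show: chloro in place of butyl gives a 5.5-fold lower number from compound 2 to compound 3 (0.74 log units; beyond the scatter) and chloro in place of ethyl gives a 4.3-fold lower number from compound 1 to compound 3 (0.63 log units; beyond the scatter) in the same direction. Both steps lie beyond the scatter, so compound 3 stands apart from the two alkyl amides. Nothing available explains this difference.

Going by these compounds, whether the drop follows from chloro itself or from the shorter chain remains open. Methyl, bromo or an amine on the same carbon would help separate those readings.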